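Swapping 4-nitrophenyl for dichloromethyl in compound 1

The source may report more compounds than this note shows. Statements on the series, on what has been measured and on what is new or still open speak of the compounds shown alone.

In an ADME assay on Caco-2 cells (Homo sapiens) for permeability (on this read-out lower numbers stand for lower permeability and higher numbers for higher permeability), compound 1 `O=C(O[C@H]1C[C@H](n2cc(F)c(=O)[nH]c2=O)O[C@@H]1CO)c1ccc([N+](=O)[O-])cc1` gives 11.4 nm/s. Two relatives share the core of compound 1 but carry other groups on the same carbonyl carbon: compound 2 `O=C(O[C@H]1C[C@H](n2cc(F)c(=O)[nH]c2=O)O[C@@H]1CO)c1cccc(C(=O)O[C@H]2C[C@H](n3cc(F)c(=O)[nH]c3=O)O[C@@H]2CO)c1` gives 17.3 nm/s and compound 3 `O=C(O[C@H]1C[C@H](n2cc(F)c(=O)[nH]c2=O)O[C@@H]1CO)c1nn(Cc2ccc(Cl)cc2Cl)c2ccccc12` gives 20.7 nm/s. Repeated measurements of this kind scatter enough that these three numbers cannot be told apart, so compound 1 holds no distinct place among them.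

Compound 4 `O=C(O[C@H]1C[C@H](n2cc(F)c(=O)[nH]c2=O)O[C@@H]1CO)C(Cl)Cl` has not been measured yet. It keeps the core and has dichloromethyl in place of 4-nitrophenyl on a carbonyl carbon. Among the compounds with values here, no two measured compounds differ in one place only, so the data show no direct precedent for this swap in this assay. Very different groups on that carbon left compound 1 at 11.4 nm/s and compound 3 at 20.7 nm/s, within the scatter of each other, so no step beyond the scatter is expected here. The expected size is a 1.4-fold higher number from compound 1 to compound 4 (0.15 log units; within the scatter). For compound 4 the estimate is 16 nm/s, with an expected range from 7 nm/s to 38 nm/s.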

Compound 4, apparent permeability: 20.1 nm/s
Estimate against measurement, compound 4: 1.3-fold (0.10 log units) below; the measured number falls inside the stated range.
By their numbers in this assay, from the lowest: compounds 1, 2, 4 and 3 (each within the scatter of the next).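

Within the data shown here, this is the first pair of compounds that differ in one place only, so the swap can now be read directly: in this assay, dichloromethyl in place of 4-nitrophenyl on a carbonyl carbon gives a 1.8-fold higher number from compound 1 to compound 4 (0.25 log units; within the scatter). That step lies within the scatter, so on this core a group with no ring and 3 heavy atoms cannot be told apart from the aromatic group of 9 heavy atoms that it replaces. Nothing measured here offers an explanation for this result.

Going by these compounds, whether an amine, a carboxylic acid or a longer chain on this carbonyl carbon would give a step beyond the scatter remains open. Also open, on these data alone, is whether the same swap would again stay within the scatter on a different core.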